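A few compounds are considered here, and "the series" means these few. Any claim that something is new, unique, unknown or untested is made for them only; others in the source may bear on it.

Among the measured compounds shown here, in a functional assay on NCI-H1975 cells (Homo sapiens) for antiproliferative activity, with a stated time of 72 h (a higher number here means a weaker inhibitor of growth, a lower number a stronger inhibitor of growth), compound 2 (`COc1ccc(CN(C)C(=O)c2cc(Cl)c(O)cc2O)cc1`) gives 16700 nM and holds the lower of the two numbers so far, with compound 1 (`CNC(=O)c1ccc(CN(C)C(=O)c2cc(Cl)c(O)cc2O)cc1`) at 34800 nM as its only neighbour. Compound 3 (`CCCNC(=O)c1ccc(CN(C)C(=O)c2cc(Cl)c(O)cc2O)cc1`) is still unmeasured and has propylcarbamoyl in place of methoxy on an aromatic carbon. For the measured compounds named here, the one measured step bearing on this is a 2.1-fold lower number from compound 1 to compound 2 (0.32 log units; beyond the scatter) and it is modest, so a return to a carbamoyl group, here with a propyl chain not yet tested, is expected to raise the number modestly. In this assay the estimated step is a 1.6-fold higher number from compound 2 to compound 3 (0.19 log units; within the scatter) as a modest rise. Compound 3 is expected at 26000 nM (range 11000 nM to 60000 nM).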

Compound 3, concentration for 50% growth inhibition: 20800 nM
The estimate for compound 3 lay 1.3-fold (0.10 log units) above the measured number, and the stated range covers the measured number.
By their numbers in this assay, from the lowest: compounds 2, 3 and 1 (each within the scatter of the next, the first and the last beyond it).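

In this assay, propylcarbamoyl in place of methoxy para to a large group gives a 1.2-fold higher number from compound 2 to compound 3 (0.10 log units; within the scatter), so at this position a carbamoyl group with a propyl chain stays level with methoxy, which the methylcarbamoyl compound did not show. Ethyl in place of hydrogen on the saturated chain gives a 1.7-fold lower number from compound 1 to compound 3 (0.22 log units; within the scatter) and so also stays within the scatter. Nothing available explains either step. Still open, from the compounds shown here alone, is whether a longer chain on the amide nitrogen, or an amine or a carboxylic acid at this position, would move the number beyond the scatter.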